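This account rests on a few compounds, and the source may have more. Where it says the series, first, only, none or still open, it means among the compounds named here.

Working notes on the chain carried on the aromatic nitrogen, followed in a functional assay on HT-29 cells (Homo sapiens) for inhibition, read by luminescence and CellTiter-Glo, with a stated time of 24 h; a higher number here means that more compound is needed for the effect, a lower number that less compound is needed. Compound 1 `CCCCCn1nc(C(=O)N[C@H]2COc3ccccc3N(C)C2=S)nc1Cc1ccccc1` gives 805 nM, compound 2 `CN1C(=S)[C@@H](NC(=O)c2nc(Cc3ccccc3)n(CCCF)n2)COc2ccccc21` gives 4760 nM and compound 3 `COCCn1nc(C(=O)N[C@H]2COc3ccccc3N(C)C2=S)nc1Cc1ccccc1` gives 566 nM. Among the compounds with values here, no measured compound lies clearly below compound 3. Its smallest step is a 1.4-fold lower number from compound 1 to compound 3 (0.15 log units; within the scatter), and its largest is an 8.4-fold lower number from compound 2 to compound 3 (0.92 log units; beyond the scatter).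

Compound 4 `CN1C(=S)[C@@H](NC(=O)c2nc(Cc3ccccc3)n(CCCCC#N)n2)COc2ccccc21` has 2-cyanoethyl in place of methoxy on a saturated chain carbon, two bonds along the chain from an aromatic nitrogen. The same difference reads 2-methoxyethyl to 4-cyanobutyl.

Within the data shown here, no measured compound carries this group, so only the steps on this chain bear on it. Besides those above, there is a 5.9-fold higher number from compound 1 to compound 2 (0.77 log units; beyond the scatter). These steps show that changes on this chain can stay within the scatter or go modestly beyond it. With compound 3 at the low end of the numbers, a modest move to a higher number is expected in this assay, though one within the scatter cannot be excluded. The expected step is a 2.5-fold higher number from compound 3 to compound 4 (0.39 log units; beyond the scatter). For compound 4 the estimated value is 1400 nM, with an expected range of 400 nM to 4800 nM.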

Compound 4, half-maximal effective concentration: 2680 nM
Beside the measured number, compound 4's estimate is 1.9-fold (0.28 log units) below it; measured number inside the range.
By their numbers in this assay, from the lowest: compounds 3 and 1 (each within the scatter of the next); then compounds 4 and 2 (each within the scatter of the next).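

In this assay, cyano in place of methyl on a saturated chain carbon, four bonds along the chain from an aromatic nitrogen, gives a 3.3-fold higher number from compound 1 to compound 4 (0.52 log units; beyond the scatter), and 2-cyanoethyl in place of methoxy gives a 4.7-fold higher number from compound 3 to compound 4 (0.68 log units; beyond the scatter), so a second chain now separates from compounds 1 and 3, where earlier only compound 2 did. Cyanomethyl in place of fluoro gives a 1.8-fold lower number from compound 2 to compound 4 (0.25 log units; within the scatter), so compounds 2 and 4 cannot be told apart, and the four compounds fall into two groups: compounds 1 and 3, and compounds 2 and 4. Nothing available explains these steps.

Going by these compounds, whether an amine or a carboxylic acid on this chain would fall with compounds 1 and 3 or with compounds 2 and 4 stays open. So does the effect of a hydroxyl group at the same place.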